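Compound 2 to compound 4: an exchange with no measured guide

The source may report more compounds than this note shows. Statements on the series, on what has been measured and on what is new or still open speak of the compounds shown alone.

compound 1 `CCc1nc2c(C)cc(-c3ccc(CN4CCC(O)CC4)cc3)cn2c1NC(=O)OCc1cc(Cl)cc(Cl)c1` gives 1580 nM
compound 2 `CCc1nc2c(C)cc(-c3ccc(CN4CCN(C)CC4)cc3)cn2c1NC(=O)OCc1cc(Cl)cc(Cl)c1` gives "nd" (no result reported)
compound 3 `CCc1nc2c(C)cc(-c3ccc(CNCCO)cc3)cn2c1NC(=O)OCc1cc(Cl)cc(Cl)c1` gives > 20000 nM

In a functional assay on MDA-MB-231 cells (Homo sapiens) for inhibition, read by MTT assay, with a stated time of 72 h (on this read-out higher numbers stand for weaker inhibition and lower numbers for stronger inhibition), only compound 1 has a measured number. For compound 3 the entry > 20000 nM is a limit of the assay and not a number. Compound 2 has no place on this scale, since its entry is "nd" (no result reported) and gives no number to start from.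

Compound 4 `CCc1nc2c(C)cc(-c3ccc(CN4CCN(C)CC4)cc3)cn2c1NC(=O)OCc1ccc(C(F)(F)F)cc1` differs from compound 2 in one place (4-(trifluoromethyl)phenyl in place of 3,5-dichlorophenyl on a saturated chain carbon bound to an oxygen next to a carbonyl group), with 4-(trifluoromethyl)phenyl in place of 3,5-dichlorophenyl on a saturated chain carbon bound to an oxygen next to a carbonyl group. Among the compounds with values here, the only measured step, which is large, is an at least 12-fold higher number from compound 1 to compound 3 (1.10 log units; beyond the scatter) and it concerns (2-hydroxyethyl)amino in place of 4-hydroxypiperidin-1-yl on a saturated chain carbon bound to an aromatic carbon. All three measured compounds carry 3,5-dichlorophenyl, so that step does not bear directly on this exchange. In this assay no step beyond the scatter is therefore expected, and no direction can be given. Within the data shown here, compound 1 at 1580 nM is the only number to lean on, although compound 4 keeps the side chain of compound 2 rather than that of compound 1. For compound 4 a value near 2500 nM is expected, with an estimated range from 600 nM to 12000 nM in this wide guess.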

Compound 4, half-maximal inhibitory concentration: 4310 nM
The estimate for compound 4 lay 1.7-fold (0.24 log units) below the measured number; low and high end bracket the measured number.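

In this assay, within the data shown here, the entry of compound 2 gives no number, so the exchange of 3,5-dichlorophenyl for 4-(trifluoromethyl)phenyl between compound 2 and compound 4 yields no step that can be read. The compounds shown leave open what this exchange does to inhibition of these cells. Nothing given here bears on the result for compound 4.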